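This account rests on a few compounds, and the source may have more. Where it says the series, first, only, none or still open, it means among the compounds named here.

Compound 1 `O/N=C(/CSc1nnc(-c2ccccc2)n1-c1ccccc1)c1ccccc1` and compound 2 `O=C(CSc1nnc(-c2ccccc2)n1-c1ccccc1)c1ccccc1` share one core and differ only at the end of the chain on sulfur. In a functional assay on the whole organism (strain albino) for inhibition, with Rattus norvegicus as the target, read by paw edema, with a stated time of 1 h, at a dose of 0.28 mmol/kg by the oral route (a higher number here means more inhibition at the dose given (going by the name of the read-out), a lower number less inhibition), compound 1 gives 60%, and in this assay compound 2 gives 53%. The step of a number 7 percentage points lower from compound 1 to compound 2 (within the scatter) goes with the change (a group of 8 heavy atoms (7 carbon, 1 oxygen; one six-membered aromatic ring of carbon only) in place of a group of 9 heavy atoms (7 carbon, 1 nitrogen, 1 oxygen; one six-membered aromatic ring of carbon only), on a saturated chain carbon bound to a sulfur). Compound 3 `C=CCn1c(SC/C(=N/O)c2ccccc2)nnc1-c1cc(OC)c(OC)c(OC)c1` rests on another core, and in this assay compound 3 gives 61%. The difference between the core of compound 3 and the core of compound 1 is not broken down here.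

Compound 4 `C=CCn1c(SCC(=O)c2ccccc2)nnc1-c1cc(OC)c(OC)c(OC)c1` has not yet been measured in this assay. It differs from compound 3 by a group of 8 heavy atoms (7 carbon, 1 oxygen; one six-membered aromatic ring of carbon only) in place of a group of 9 heavy atoms (7 carbon, 1 nitrogen, 1 oxygen; one six-membered aromatic ring of carbon only), on a saturated chain carbon bound to a sulfur. Among the measured compounds shown here, this is the same change, at the same place, as the one from compound 1 to compound 2. Because the step of a number 7 percentage points lower from compound 1 to compound 2 (within the scatter) came from this same change, compound 4 is expected to move by a step of similar size, a number 6 percentage points lower from compound 3 to compound 4 (within the scatter). Compound 4 is therefore estimated to give 55% in this assay, with a range from 43% to 66%.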

Compound 4, a percentage reported as inhibition, in the whole organism at one dose (the size of the read-out at that dose, not a potency): 49%
For compound 4 the middle estimate is 6 percentage points above the measured one; the measured number falls inside the stated range.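

In this assay, the change to benzoyl on a saturated chain carbon bound to a sulfur brings a number 12 percentage points lower from compound 3 to compound 4 (beyond the scatter), and this step can be set beside the earlier one on the core of compound 1: the same change on two cores in this assay, a number 7 percentage points lower (within the scatter) from compound 1 to compound 2 and a number 12 percentage points lower (beyond the scatter) from compound 3 to compound 4, 5 percentage points apart, within the scatter of two such steps. On these two cores the change therefore goes the same way and the sizes of the two steps cannot be told apart, although only the newer step lies beyond the scatter when taken alone. This rests on two matched pairs at a single dose and time, and it does not show that the step would hold on any further core, nor does it say what lies behind the step.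

The compounds shown leave open how other groups would read at this place, such as an amine or a carboxylic acid in place of the benzoyl group. They also leave open whether the same step would appear on a longer chain bound to the sulfur.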